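A few compounds are considered here, and "the series" means these few. Any claim that something is new, unique, unknown or untested is made for them only; others in the source may bear on it.

The series was profiled in an assay on membranes from Sf9 cells for displacement of a labelled ligand from histamine H2 receptor (Homo sapiens), read by scintillation counting, with a stated time of 60 min; a higher number here means a weaker inhibitor, a lower number a stronger inhibitor. Compound 1 `Cc1nc(N)sc1CCCN/C(N)=N/C(=O)N[C@H](C)c1ccccc1` gives 17.8 nM in this assay, the lowest number of the three measured compounds. Among the compounds with values here, compound 2 `CCCCCCNC(=O)/N=C(\N)Nc1cccc(-c2csc(N)n2)c1` gives 692 nM, and compound 3 `N/C(=N\C(=O)NC1CCCCC1)Nc1cccc(-c2csc(N)n2)c1` gives 4470 nM; the one step measured within this set, a 6.5-fold higher number from compound 2 to compound 3 (0.81 log units; beyond the scatter), concerns a different substituent on a different core, so it does not bear directly on the change considered here.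

Compound 4 `Cc1nc(N)sc1CCCN/C(N)=N/C(=O)NC(C)c1cccs1` differs from compound 1 in one place: 1-(thiophen-2-yl)ethyl in place of 1-phenylethyl on an amide-type nitrogen. Within the data shown here, no measured pair in this set exchanges one aromatic ring for another on the amide-type nitrogen, so there is no step to calibrate the expectation against. With nothing measured pointing either way, the expected step in this assay from compound 1 to compound 4 is small, a 1.4-fold higher number from compound 1 to compound 4 (0.15 log units; within the scatter), and may well fall within the scatter. Compound 4 is therefore estimated at 25 nM in this assay, with a range of 8 nM to 80 nM.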

Compound 4, inhibition constant: 63.1 nM
Compound 4: middle estimate off by 2.5-fold (0.40 log units), on the low side; measured number inside the range.
By their numbers in this assay, from the lowest: compound 1; then compound 4; then compound 2; then compound 3.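

The exchange of 1-phenylethyl for 1-(thiophen-2-yl)ethyl on the amide-type nitrogen gives a 3.5-fold higher number from compound 1 to compound 4 (0.55 log units; beyond the scatter) in this assay, so this position on the shared core responds to replacing one aromatic ring with another, and the six-membered carbon ring gives the lower number. The entering group carries no defined stereocentre, whereas the leaving group carries one, so this single step does not separate the ring exchange from the stereochemical difference. Nothing available explains the size or direction of this step.

Still open, going by these compounds, is how each separate form of the 1-(thiophen-2-yl)ethyl group would compare with compound 1. On these data alone, it is also open whether a 1-(pyridin-2-yl)ethyl or a plain benzyl group on the same nitrogen would stay close to compound 1 or move further from it.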